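Moving a methyl group: expected toxicity of compound 4

The source may report more compounds than this note shows. Statements on the series, on what has been measured and on what is new or still open speak of the compounds shown alone.

Compound 3 `COc1ccc(-c2cnc(NC(=O)c3ccc(C)cc3)n2C)cc1` was tested in a toxicity assay on THP-1 cells (Homo sapiens) for inhibition; on this read-out lower numbers stand for higher toxicity in this test and higher numbers for lower toxicity in this test. Compound 3 gives > 100000 nM, which is a limit of the assay and not a number. Two further compounds share its core and differ only in the group on the carbonyl carbon. Compound 1 `COc1ccc(-c2cnc(NC(=O)c3ccccc3OC)n2C)cc1` carries a 2-methoxyphenyl there; in this assay compound 1 gives > 100000 nM, again a limit. Compound 2 `COc1ccc(-c2cnc(NC(=O)C3CCOCC3)n2C)cc1` carries an oxan-4-yl there; in this assay compound 2 gives > 100000 nM, also a limit. Compound 3 therefore stands where every measured compound stands, because of the limit of > 100000 nM in this assay, at which 3 of the 3 values shown sit.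

Compound 4 `COc1ccc(-c2cnc(NC(=O)c3ccccc3C)n2C)cc1` has not yet been measured. It differs from compound 3 in a single respect: 2-methylphenyl in place of 4-methylphenyl on a carbonyl carbon.

The measured steps that bear on this are a step that the two limits leave unreadable from compound 1 to compound 3, a step that the two limits leave unreadable from compound 2 to compound 3 and a step that the two limits leave unreadable from compound 1 to compound 2. Each joins two limits, so none of them shows how large a change of the group on the carbonyl carbon moves the read-out, or in which direction. The present change is smaller than any of those, as the same atoms are merely joined differently.

Compound 4 is therefore expected to remain at the same limit, a step of a number no higher from compound 3 to compound 4 (the limit leaves the size open) being the expectation. The estimate for compound 4 is 100000 nM, with a range from 40000 nM to 300000 nM.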

Compound 4, half-maximal cytotoxic concentration: > 100000 nM
Compound 4 gave a limit, no number; the forecaster's own chance of this, stated with the estimate: 85%; the middle value lies on the limit itself.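

In this assay compound 4 gives > 100000 nM, which is a limit of the assay and not a number. Its steps from compound 1, compound 2 and compound 3 each join two limits, so none can be read. The compounds shown leave open whether any group on the carbonyl carbon changes this read-out, because all of them share one limit: the limit of > 100000 nM in this assay, at which 4 of the 4 values shown sit.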